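The source may report more compounds than this note shows. Statements on the series, on what has been measured and on what is new or still open speak of the compounds shown alone.

Compound 1 `Nc1ccc(/C=C2\SC(=O)N(Cc3ccc(Cl)cc3)C2=O)cc1` gives 60000 nM in a functional assay on FM3A cells (Mus musculus) for cytotoxicity, read by cell counting, with a stated time of 2 days (on this read-out lower numbers stand for stronger inhibition and higher numbers for weaker inhibition), and, of the two numbers recorded for this series, it is the lowest. The nearest number belongs to compound 3 `CC(C)(C)c1ccc(CN2C(=O)S/C(=C\c3cccc(N)c3)C2=O)cc1`, which gives 188000 nM in this assay, a gap beyond the usual scatter. Compound 2 `Nc1cccc(/C=C2\SC(=O)N(Cc3cccc(F)c3)C2=O)c1` reaches only > 250000 nM in this assay, which is a limit of the assay and not a number. One of the three values thus sits at the limit of > 250000 nM in this assay, at which 1 of the 3 values shown sits. Compound 4 `CN1C(=O)S/C(=C\c2ccc(N)cc2)C1=O` is not yet measured in this assay; it differs from compound 1 by hydrogen in place of 4-chlorophenyl on a saturated chain carbon bound to an amide-type nitrogen in a ring. For the measured compounds named here, no measured step of this kind exists here, so the expected step of a 2.5-fold higher number from compound 1 to compound 4 (0.40 log units; beyond the scatter) is taken to run toward weaker inhibition, beyond the scatter. Compound 4 is accordingly expected to give about 150000 nM in this assay, estimated between 50000 nM and 400000 nM.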

Compound 4, half-maximal inhibitory concentration: 107000 nM
Compound 4: the middle estimate sits 1.4-fold (0.15 log units) above what was measured; the range from low to high includes it.
By their numbers in this assay, from the lowest: compounds 1, 4 and 3 (each within the scatter of the next, the first and the last beyond it). At a limit, above all of these: compound 2.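

In this assay the step of a 1.8-fold higher number from compound 1 to compound 4 (0.25 log units; within the scatter) comes with hydrogen in place of 4-chlorophenyl on a saturated chain carbon bound to an amide-type nitrogen in a ring. For the compounds shown here, this is the first one-place change that can be read, and the 4-chlorophenyl proves dispensable here, since losing it does not move the number beyond the scatter. Nothing measured here gives a cause for this step. Still open, from the compounds shown here alone, is whether a longer chain, an amine or a carboxylic acid in place of 4-chlorophenyl would shift the number beyond the scatter.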